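Swapping the amine ring and shortening the linker

The source may report more compounds than this note shows. Statements on the series, on what has been measured and on what is new or still open speak of the compounds shown alone.

Measured compounds:
compound 1, `COc1cc2oc(-c3ccccc3)cc(=O)c2c(O)c1OCCCCN1CCN(C)CC1`, a functional assay on HepG2 cells (Homo sapiens) for antiproliferative activity, read by MTT assay, with a stated time of 48 h; a lower number here means a stronger inhibitor, a higher number a weaker inhibitor: 36700 nM
compound 2, `COc1cc2oc(-c3ccccc3)cc(=O)c2c(O)c1OCCCCN1CCCCC1`, this assay: 21000 nM

Compound 2 has the lower of the two numbers in this assay, yet the gap to compound 1, a 1.7-fold lower number from compound 1 to compound 2 (0.24 log units; within the scatter), lies within the scatter, so the two cannot be told apart. Compound 3, `COc1cc2oc(-c3ccccc3)cc(=O)c2c(O)c1OCCCN1CCN(C)CC1`, differs from compound 2 by 4-methylpiperazin-1-yl in place of (piperidin-1-yl)methyl on a saturated chain carbon, three bonds along the chain from an oxygen on an aromatic ring. Within the data shown here, only the step from compound 1 to compound 2 bears on this change, and it was small; no measured pair speaks to the shorter chain. The step is therefore expected to be a 1.4-fold higher number from compound 2 to compound 3 (0.15 log units; within the scatter), and compound 3 is estimated at 30000 nM, between 12000 nM and 75000 nM.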

Compound 3, half-maximal inhibitory concentration: 15100 nM
Compound 3: middle estimate off by 2.0-fold (0.30 log units), on the high side; the measured number falls inside the stated range.
By their numbers in this assay, from the lowest: compounds 3, 2 and 1 (each within the scatter of the next, the first and the last beyond it).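

Among these compounds, compound 1 and compound 3 carry the same 4-methylpiperazin-1-yl ring, so this pair gives the first reading of chain length alone: in this assay the shorter chain gives a 2.4-fold lower number from compound 1 to compound 3 (0.39 log units; beyond the scatter) and the change counts as real. The step that alters ring and chain together, a 1.4-fold lower number from compound 2 to compound 3 (0.14 log units; within the scatter), does not separate its two compounds. No measurement here explains the effect of the chain.

On these data alone, whether a piperidin-1-yl ring responds to the shorter chain in the same way remains open. So does the outcome with a still shorter 2-(4-methylpiperazin-1-yl)ethyl chain or a morpholine ring.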